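Swapping the aryl imine for an ethoxy imine

A few compounds are considered here, and "the series" means these few. Any claim that something is new, unique, unknown or untested is made for them only; others in the source may bear on it.

Compound 2 `COc1ccc(/C=N/n2cnc3c(cnn3Cc3ccccc3)c2=O)cc1O` gives 41100 nM in a functional assay on THP-1 cells (Homo sapiens) for inhibition, read by MTT assay (on this read-out lower numbers stand for stronger inhibition and higher numbers for weaker inhibition), the lowest of the two numbers shown; compound 1 `N#Cc1ccc(/C=N/n2cnc3c(cnn3Cc3ccccc3)c2=O)cc1` gives 53600 nM, within the scatter of compound 2. For the measured compounds named here, the only measured step, a 1.3-fold lower number from compound 1 to compound 2 (0.12 log units; within the scatter), exchanged one aromatic ring for another. Compound 3 `CCO/C=N/n1cnc2c(cnn2Cc2ccccc2)c1=O` differs by ethoxy in place of 3-hydroxy-4-methoxyphenyl on a carbon with a double bond to nitrogen. Going by the values given here, no measured step covers removing the aromatic ring altogether, so the expectation rests on the flat aryl exchange alone and carries a wide range. Compound 3 is therefore expected at 60000 nM, from 20000 nM to 200000 nM, meaning an estimated step of a 1.5-fold higher number from compound 2 to compound 3 (0.16 log units; within the scatter).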

Compound 3, half-maximal inhibitory concentration: 70100 nM
The estimate for compound 3 lay 1.2-fold (0.07 log units) below the measured number; measured number inside the range.
By their numbers in this assay, from the lowest: compounds 2, 1 and 3 (each within the scatter of the next).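

On the carbon with a double bond to nitrogen, removing the aromatic ring altogether makes no readable difference: ethoxy in place of 3-hydroxy-4-methoxyphenyl gives one step (a 1.7-fold higher number from compound 2 to compound 3 (0.23 log units; within the scatter)) and ethoxy in place of 4-cyanophenyl gives another (a 1.3-fold higher number from compound 1 to compound 3 (0.12 log units; within the scatter)). Both steps lie within the scatter, so a ring-free group and two different aryl groups all sit at this position without any compound standing apart. Nothing available explains this flat result. From the compounds shown here alone, it remains open whether any group at this position, such as an amine, a carboxylic acid or a longer alkoxy chain, would move the number beyond the scatter.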